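The compounds below may be only part of what the source reports. "The series", "measured", "known", "first", "only" and "open" are said of these compounds alone.

Compound 3 `CCN1CCN(c2cc(C)c3cc(NC(=O)c4ccccc4Cl)ccc3n2)CC1` is one of a small set of amides sharing a common core. In a functional assay on SK-BR-3 cells (Homo sapiens) for antiproliferative activity, read by MTT assay, with a stated time of 72 h (on this read-out higher numbers stand for weaker inhibition and lower numbers for stronger inhibition), compound 3 gives only a limit of the assay, > 50000 nM. Compound 2 `CCN1CCN(c2cc(C)c3cc(NC(=O)c4ccc(Cl)cc4)ccc3n2)CC1` gives 3020 nM, and compound 1 `Cc1cc(NCCN2CCN(C)CC2)nc2ccc(NC(=O)c3ccc(Cl)c(Cl)c3)cc12`, which carries the same 3,4-dichlorophenyl group on a different core, gives 2690 nM. Compound 4 `CCN1CCN(c2cc(C)c3cc(NC(=O)c4ccc(Cl)c(Cl)c4)ccc3n2)CC1` has not yet been measured; it differs from compound 3 by 3,4-dichlorophenyl in place of 2-chlorophenyl on a carbonyl carbon. Going by the values given here, the only measured step touching this part, an at least 16-fold higher number from compound 2 to compound 3 (1.21 log units; beyond the scatter), shows that the 2-chlorophenyl amide falls to the limit of > 50000 nM in this assay, at which 1 of the 3 values shown sits. Compound 4 is therefore expected to move strongly back toward stronger inhibition, by about an at least 20-fold lower number from compound 3 to compound 4 (1.30 log units; beyond the scatter), because compound 2 gives 3020 nM. Compound 4 is estimated at 2500 nM, between 800 nM and 8000 nM.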

Compound 4, half-maximal inhibitory concentration: 2160 nM
Compound 4: middle estimate off by 1.2-fold (0.06 log units), on the high side; the measured number falls inside the stated range.
By their numbers in this assay, from the lowest: compounds 4, 1 and 2 (each within the scatter of the next). At a limit, above all of these: compound 3.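

Compound 3 sits at a limit of the assay: the limit of > 50000 nM in this assay, at which 1 of the 4 values shown sits. Placing 3,4-dichlorophenyl on a carbonyl carbon in this assay gives an at least 23-fold lower number from compound 3 to compound 4 (1.36 log units; beyond the scatter), so the second chlorine does not carry the loss seen with 2-chlorophenyl into this amide. Adding chloro in place of hydrogen on an aromatic carbon gives a 1.4-fold lower number from compound 2 to compound 4 (0.15 log units; within the scatter), and 4-ethylpiperazin-1-yl in place of (2-(4-methylpiperazin-1-yl)ethyl)amino gives a 1.2-fold lower number from compound 1 to compound 4 (0.10 log units; within the scatter), so neither change separates these compounds.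

The compounds shown leave open whether 2-chlorophenyl on the core of compound 1 would also reach a limit. They also leave open whether an amine or a carboxylic acid in place of chloro on the phenyl ring would hold this level.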